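Swapping the aryl amine on the shared core

The source may report more compounds than this note shows. Statements on the series, on what has been measured and on what is new or still open speak of the compounds shown alone.

Of the compounds shown here, three with a common core have been tested in a functional assay on HCC827 cells (Homo sapiens) for inhibition, read by MTT assay, with a stated time of 48 h, tested at 10 uM; on this read-out higher numbers stand for more inhibition at the one concentration tested (going by the name of the read-out) and lower numbers for less inhibition. Compound 1 `Cc1ccc(Nc2cc(NC(=O)Nc3c(Cl)cccc3Cl)ncn2)cc1C` gives 84.3%, compound 2 `COc1ccc(Br)cc1Nc1cc(NC(=O)Nc2c(Cl)cccc2Cl)ncn1` gives 53% and compound 3 `COc1ccc(Nc2cc(NC(=O)Nc3c(Cl)cccc3Cl)ncn2)cc1C` gives 63.1%. Compound 3 thus stands second highest of the three, with compound 2 a number 10.1 percentage points higher from compound 2 to compound 3 (beyond the scatter) and compound 1 a number 21.2 percentage points lower from compound 1 to compound 3 (beyond the scatter). The untested compound 4 `O=C(Nc1cc(Nc2ccc(F)c(Cl)c2)ncn1)Nc1c(Cl)cccc1Cl` differs from compound 3 in one place: 3-chloro-4-fluorophenyl in place of 4-methoxy-3-methylphenyl on a nitrogen on an aromatic ring. The measured steps that change the aryl group on this nitrogen are the ones that bear on it, and they were sizeable, a number 31.3 percentage points lower from compound 1 to compound 2 (beyond the scatter) and a number 10.1 percentage points higher from compound 2 to compound 3 (beyond the scatter); the smaller change a number 21.2 percentage points lower from compound 1 to compound 3 (beyond the scatter) shows that even one substituent on that ring shifts the read-out beyond the scatter. Within the data shown here, since a ring with two halogens has no measured precedent here, the direction is open, but compound 4 is expected to stay in the range of its neighbours, with a step of a number 6.9 percentage points higher from compound 3 to compound 4 (within the scatter) estimated to remain within the scatter. Compound 4 is therefore estimated at 70%, between 50% and 88%.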

Compound 4, a percentage reported as inhibition, at one concentration (the size of the read-out at that concentration, not a potency): 53.7%
Compound 4: the middle estimate sits 16.3 percentage points above what was measured; low and high end bracket the measured number.
By their numbers in this assay, from the lowest: compounds 2, 4 and 3 (each within the scatter of the next, the first and the last beyond it); then compound 1.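

In this assay the change to 3-chloro-4-fluorophenyl on this nitrogen gives a number 9.4 percentage points lower from compound 3 to compound 4 (within the scatter) and a number 0.7 percentage points higher from compound 2 to compound 4 (within the scatter) as well, so a ring with two halogens cannot be told apart from either the 4-methoxy-3-methylphenyl or the 5-bromo-2-methoxyphenyl ring. Among these compounds, the 3,4-dimethylphenyl ring remains the one group here whose steps to all the others lie beyond the scatter, and the new comparison adds a number 30.6 percentage points lower from compound 1 to compound 4 (beyond the scatter) to that picture. Nothing at hand gives a reason for this separation.

Going by these compounds, what a ring with a single chlorine or a single fluorine would give stays open, as does the effect of an amine or a carboxylic acid on the ring. On these data alone, it also remains open whether one methyl or both set the 3,4-dimethylphenyl ring apart.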